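Extending the alkoxy chain toward a cyclohexylpropoxy group

The source may report more compounds than this note shows. Statements on the series, on what has been measured and on what is new or still open speak of the compounds shown alone.

Measured compounds:
compound 1 `CCCOc1c(C(=O)N(C)Cc2cc(C(F)(F)F)cc(C(F)(F)F)c2)c(=O)n(C)c2ccccc12` in an assay on cells for inhibition of phosphatidylcholine:ceramide cholinephosphotransferase 2 (Homo sapiens), read by mass spectrometry, with stated times of 60 min and 30 min (on this read-out lower numbers stand for stronger inhibition and higher numbers for weaker inhibition), gives 2100 nM
compound 2 `CC(C)CCOc1c(C(=O)N(C)Cc2cc(C(F)(F)F)cc(C(F)(F)F)c2)c(=O)n(C)c2ccccc12` in this assay gives 350 nM

Compound 2 stands at the lowest of the two numbers; its nearest neighbour, compound 1, reads a 6.0-fold lower number from compound 1 to compound 2 (0.78 log units; beyond the scatter). That single measured step is the only one available, and it describes the same place: the saturated chain carbon two bonds along the chain from the oxygen on the aromatic ring.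

Compound 3 `CN(Cc1cc(C(F)(F)F)cc(C(F)(F)F)c1)C(=O)c1c(OCCCC2CCCCC2)c2ccccc2n(C)c1=O` differs from compound 2 by cyclohexylmethyl in place of isopropyl on a saturated chain carbon, two bonds along the chain from an oxygen on an aromatic ring. The step from compound 1 to compound 2 enlarged the group at this place and brought a lower number, so a further enlargement is expected to move the number in the same direction, though nothing measured tells how far such growth keeps paying. Compound 3 is therefore expected to show a 2.3-fold lower number from compound 2 to compound 3 (0.37 log units; beyond the scatter), a modest step downward. The estimate for compound 3 in this assay is 150 nM, with a range from 40 nM to 600 nM.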

Compound 3, half-maximal inhibitory concentration: 480 nM
Compound 3: the middle estimate sits 3.2-fold (0.51 log units) below what was measured, within the range that was stated.
By their numbers in this assay, from the lowest: compounds 2 and 3 (each within the scatter of the next); then compound 1.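

In this assay, replacing isopropyl with cyclohexylmethyl at this saturated chain carbon gives a 1.4-fold higher number from compound 2 to compound 3 (0.14 log units; within the scatter), so compound 2 and compound 3 cannot be separated, and the further enlargement does not extend the trend seen with the first step. The added six-membered ring of carbon is still tolerated at this place: placing cyclohexyl on the end of the chain gives a 4.4-fold lower number from compound 1 to compound 3 (0.64 log units; beyond the scatter), a step beyond the scatter. No available evidence bears on this result.

The compounds shown leave open whether the number would change with a phenyl ring in place of the cyclohexyl ring, or with a longer chain between the oxygen and the ring. They also leave open how an amine or a carboxylic acid at the end of the chain would read.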